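Oxime ether variants on a flavone series: methylation step

The source may report more compounds than this note shows. Statements on the series, on what has been measured and on what is new or still open speak of the compounds shown alone.

Compound 1 `O=c1cc(-c2ccccc2)oc2ccc(OC/C(=N/O)c3ccc(F)cc3)cc12` and compound 2 `O=c1cc(-c2ccccc2)oc2cc(OC/C(=N/O)c3ccccc3)ccc12` carry the same oxime side chain but differ in their cores; the difference between the two cores is not broken down here. In a functional assay on SK-HEP1 cells (Homo sapiens) for antiproliferative activity (on this read-out lower numbers stand for stronger inhibition of growth and higher numbers for weaker inhibition of growth), compound 1 gives 2800000 nM, while compound 2 gives 2000000 nM, and these two values lie within the scatter of each other, so no order between them is claimed. Compound 3 `CO/N=C(/COc1ccc2oc(-c3ccccc3)cc(=O)c2c1)c1ccc(F)cc1` is the methylated counterpart of compound 1, with the change (methyl in place of hydrogen on an oxygen). In this assay compound 3 gives 7910000 nM, and the step of a 2.8-fold higher number from compound 1 to compound 3 (0.45 log units; beyond the scatter) is a modest weakening of growth inhibition that lies beyond the scatter.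

Compound 4 `CO/N=C(/COc1ccc2c(=O)cc(-c3ccccc3)oc2c1)c1ccccc1` is not yet measured. It relates to compound 2 as compound 3 relates to compound 1, through the change (methyl in place of hydrogen on an oxygen), which is the same change on the same kind of place on an oxygen whose other neighbour is a double-bonded nitrogen. Among the compounds with values here, with only one measured example of this step, the expectation for compound 4 rests on that example alone: the step from compound 2 to compound 4 is estimated at a 2.8-fold higher number from compound 2 to compound 4 (0.45 log units; beyond the scatter), sized after compound 1 going to compound 3 with a 2.8-fold higher number from compound 1 to compound 3 (0.45 log units; beyond the scatter). In this assay compound 4 is therefore expected to give about 5600000 nM, with a plausible range from 2500000 nM to 12000000 nM, so that it is expected to remain a weak inhibitor of growth like the three measured compounds.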

Compound 4, concentration for 50% growth inhibition: 2000000 nM
Compound 4: middle estimate off by 2.8-fold (0.45 log units), on the high side; measured number below the stated range.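

In this assay, methyl in place of hydrogen on the oxygen whose other neighbour is a double-bonded nitrogen gives no change at the digits printed from compound 2 to compound 4 (within the scatter), so on the core of compound 2 this change has no readable effect on growth inhibition. The step therefore does not carry over in size from one pair to the other, as the earlier step on the core of compound 1 is a 2.8-fold higher number from compound 1 to compound 3 (0.45 log units; beyond the scatter), and the two steps differ by more than their scatter: the same change on two cores in this assay, a 2.8-fold higher number (0.45 log units; beyond the scatter) from compound 1 to compound 3 and no change at the digits printed (within the scatter) from compound 2 to compound 4, 2.8-fold (0.45 log units) apart, beyond the scatter of two such steps

Within the data shown here, this shows that the size of the methyl step depends on the pair in which it is read, but it does not show what sets that size, since there are only two pairs and they differ in the core and also in the fluorine carried by compound 1 and compound 3.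

Open, as far as these compounds go, is whether a longer chain on that oxygen, or a chain ending in an amine or a carboxylic acid, would move the number on either core. Also open, from the compounds shown here alone, is how the step reads on the core of compound 1 without the fluorine or on the core of compound 2 with it, which would separate the part played by the core from that of the fluorine.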